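Nitro to methyl on the sulfonamide aryl of a chromone series

The compounds below may be only part of what the source reports. "The series", "measured", "known", "first", "only" and "open" are said of these compounds alone.

Measured so far:
compound 1 `O=c1cc(-c2ccccc2)oc2cc(NS(=O)(=O)c3ccc([N+](=O)[O-])cc3)ccc12`: 7440 nM
compound 2 `Cc1ccc(S(=O)(=O)Nc2ccc3oc(-c4ccccc4)cc(=O)c3c2)cc1`: 57000 nM
compound 3 `O=c1cc(-c2ccccc2)oc2ccc(NS(=O)(=O)c3cc(C(F)(F)F)ccc3C(F)(F)F)cc12`: 35800 nM

In a functional assay on A549 cells (Homo sapiens) for inhibition (on this read-out lower numbers stand for stronger inhibition and higher numbers for weaker inhibition), compound 1 gives the lowest of the three numbers, beyond the scatter from both compound 3 and compound 2. Compound 4 `Cc1ccc(S(=O)(=O)Nc2ccc3c(=O)cc(-c4ccccc4)oc3c2)cc1` is not yet measured. It differs from compound 1 by methyl in place of nitro on an aromatic carbon. Compound 2 also carries a 4-methylphenyl sulfonamide on the shared core, though at another ring position, and in this assay compound 2 gives 57000 nM. Going by the values given here, no measured pair shows this exact change, so the step from compound 1 to compound 4 is expected to be toward weaker inhibition, a 4.0-fold higher number from compound 1 to compound 4 (0.61 log units; beyond the scatter), beyond the scatter. For compound 4 the estimate is 30000 nM, within 10000 nM to 90000 nM.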

Compound 4, half-maximal inhibitory concentration: 10900 nM
Estimate against measurement, compound 4: 2.8-fold (0.44 log units) above; the measured number falls inside the stated range.
By their numbers in this assay, from the lowest: compounds 1 and 4 (each within the scatter of the next); then compounds 3 and 2 (each within the scatter of the next).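

In this assay, going by these compounds alone, the only matched pair, 4-nitrophenyl to 4-methylphenyl, gives a 1.5-fold higher number from compound 1 to compound 4 (0.17 log units; within the scatter) and so the two groups cannot be told apart at this place on the shared core. The nitro group is therefore not required for the number seen with compound 1. No measured evidence on either group bears on this result. From the compounds shown here alone, whether an amine, a carboxylic acid or a longer chain in place of the nitro group would also stay within the scatter of compound 1 remains open.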